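The source may hold more compounds than are shown below. What is called first, only, known or untested is meant among the compounds shown, and "the series" means these compounds.

Compound 1 `Cc1cn2c(-c3cn[nH]c3)cnc2c(Nc2cc(Cc3ccccn3)ns2)n1`: 6880 ng.h/mL
Compound 2 `Cc1cn2c(-c3cn[nH]c3)cnc2c(Nc2cc(C(c3ccccn3)N3CCCC3)ns2)n1`: 9.15 ng.h/mL
Compound 3 `Cc1cn2c(-c3cn[nH]c3)cnc2c(Nc2cc(C(c3ccccn3)N3CCC(F)CC3)ns2)n1`: 220 ng.h/mL

In an ADME assay on the whole organism for pharmacokinetics, with Rattus norvegicus as the target, with a stated time of 6 h, at a dose of 10 mg/kg by the oral route (a lower number here means less compound in the circulation, a higher number more compound in the circulation at the dose given), compound 3 stands second highest of the three numbers: the step of a 31-fold lower number from compound 1 to compound 3 (1.50 log units; beyond the scatter) separates it from the top, and the step of a 24-fold higher number from compound 2 to compound 3 (1.38 log units; beyond the scatter) from the bottom. Compound 4 `Cc1cn2c(-c3cn[nH]c3)cnc2c(Nc2cc(C(NC(C)(C)C)c3ccccn3)ns2)n1` differs from compound 3 by (tert-butyl)amino in place of 4-fluoropiperidin-1-yl on a saturated chain carbon bound to two aromatic carbons. Among the compounds with values here, three measured steps bear on this carbon. Both a 750-fold lower number from compound 1 to compound 2 (2.88 log units; beyond the scatter) and a 31-fold lower number from compound 1 to compound 3 (1.50 log units; beyond the scatter) were large drops on replacing hydrogen with an amine, and the two amines themselves differ by a 24-fold higher number from compound 2 to compound 3 (1.38 log units; beyond the scatter). Within the data shown here, no measured step exchanges a ring amine for an open-chain amine, so the direction for compound 4 is uncertain. Compound 4 is expected to give a number near compound 3, with a step of a 2.2-fold lower number from compound 3 to compound 4 (0.34 log units; beyond the scatter), estimated at 100 ng.h/mL within the range 15 ng.h/mL to 700 ng.h/mL.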

Compound 4, area under the concentration-time curve: 735 ng.h/mL
For compound 4 the middle estimate is 7.4-fold (0.87 log units) below the measured one, outside the stated range (above it).
By their numbers in this assay, from the lowest: compound 2; then compound 3; then compound 4; then compound 1.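

In this assay, (tert-butyl)amino in place of hydrogen on this saturated chain carbon costs less than either ring amine did (a 9.4-fold lower number from compound 1 to compound 4 (0.97 log units; beyond the scatter)), though compound 1 remains highest. The open-chain amine also exceeds both ring amines (a 3.3-fold higher number from compound 3 to compound 4 (0.52 log units; beyond the scatter); an 80-fold higher number from compound 2 to compound 4 (1.90 log units; beyond the scatter)), so the loss depends strongly on which amine enters. Nothing shown here accounts for these differences.

Compound 4 alone cannot separate the effect of the open chain from that of the tert-butyl group or the amine hydrogen. Isopropylamino and dimethylamino at this carbon would bear on that question.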